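Heteroaryl exchange on the shared core

This account rests on a few compounds, and the source may have more. Where it says the series, first, only, none or still open, it means among the compounds named here.

Measured so far:
- compound 1 `O=C(O)CCc1ccc(OCc2nc(-c3ccccc3)no2)cc1`: in a functional assay on CHO cells for agonist activity at Free fatty acid receptor 1 (Homo sapiens), read by FLIPR and calcium flux, in the presence of a further agent that is not named here (a lower number here means that less compound is needed, a higher number that more compound is needed for the effect), compound 1 gives 1130 nM
- compound 2 `COc1cccc(-c2noc(COc3ccc(CCC(=O)O)cc3)n2)c1`: in this assay compound 2 gives 2670 nM
- compound 3 `O=C(O)CCc1ccc(OCc2nc(-c3cccs3)no2)cc1`: in this assay compound 3 gives 2570 nM

Compound 3 holds the second highest of the three numbers. Its value and that of compound 2 lie within the scatter of each other (a 1.0-fold lower number from compound 2 to compound 3 (0.02 log units; within the scatter)), so no order can be read between them. The step of a 2.3-fold higher number from compound 1 to compound 3 (0.36 log units; beyond the scatter) is beyond the scatter, and so is a 2.4-fold higher number from compound 1 to compound 2 (0.37 log units; beyond the scatter).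

The next compound, compound 4 `O=C(O)CCc1ccc(OCc2nc(-c3ccco3)no2)cc1`, differs from compound 3 in one place: furan-2-yl in place of thiophen-2-yl on an aromatic carbon. For the measured compounds named here, no measured step exchanges one five-membered ring for another, so the step from compound 3 to compound 4 has no direct precedent. Going by the values given here, the steps that bear on it are the exchanges at the same position, a 2.3-fold higher number from compound 1 to compound 3 (0.36 log units; beyond the scatter) and a 2.4-fold higher number from compound 1 to compound 2 (0.37 log units; beyond the scatter), both modest and both beyond the scatter, and the exchange a 1.0-fold lower number from compound 2 to compound 3 (0.02 log units; within the scatter), which lies within the scatter. On this basis a step of modest size at most is expected in this assay, most likely toward a higher number, and possibly none beyond the scatter, which is the expected step of a 1.2-fold higher number from compound 3 to compound 4 (0.10 log units; within the scatter). The value for compound 4 is estimated at 3200 nM, with a range from 1300 nM to 8000 nM.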

Compound 4, half-maximal effective concentration: > 100000 nM
Compound 4: no number, only a limit; the forecaster's own chance of this, stated with the estimate: 10%; middle value at least 31-fold (1.49 log units) away from the limit.
By their numbers in this assay, from the lowest: compound 1; then compounds 3 and 2 (each within the scatter of the next). At a limit, above all of these: compound 4.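

Compound 4 is read in this assay only as a limit, not as a number: the limit of > 100000 nM in this assay, at which 1 of the 4 values shown sits. Thiophen-2-yl and furan-2-yl have the same heavy-atom count, each is one five-membered aromatic ring with 1 hetero atom, and neither carries a net charge, yet this one exchange gives an at least 38-fold higher number from compound 3 to compound 4 (1.59 log units; beyond the scatter), so those counts do not predict the outcome at this position, on the carbon between two ring nitrogen atoms. The earlier exchanges here stayed modest or within the scatter, whereas furan-2-yl also gives an at least 37-fold higher number from compound 2 to compound 4 (1.57 log units; beyond the scatter) and an at least 88-fold higher number from compound 1 to compound 4 (1.94 log units; beyond the scatter), which makes this position far less forgiving than compounds 1, 2 and 3 suggested.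

What lies behind the step cannot be read from these compounds. From the compounds shown here alone, it remains open whether furan-3-yl or pyridin-2-yl at this position would stay near compound 3 or reach a limit as compound 4 does.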